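Methoxy addition on an aryl ring in two isoquinolinone series

The compounds below may be only part of what the source reports. "The series", "measured", "known", "first", "only" and "open" are said of these compounds alone.

Three compounds were tested in a functional assay on SK-MEL-2 cells (Homo sapiens) for cytotoxicity, read by MTT assay, with a stated time of 48 h; a lower number here means a stronger inhibitor, a higher number a weaker inhibitor. Compound 1 `COCOCc1cc(OC)ccc1-c1cc2ccccc2c(=O)[nH]1` gives 97600 nM. Compound 3 `COCOCc1cc(OC)c(OC)cc1-c1cc2ccccc2c(=O)[nH]1` gives 55200 nM. The step of a 1.8-fold lower number from compound 1 to compound 3 (0.25 log units; within the scatter) corresponds to the change (methoxy in place of hydrogen on an aromatic carbon).

Compound 2 `C=CCn1c(-c2ccc(OC)cc2C=O)cc2ccccc2c1=O` gives 88900 nM in this assay. The difference between the core of compound 2 and the core of compound 1 is not broken down here. The values of compound 2 and compound 1 lie within the usual scatter of each other, as do those of compound 2 and compound 3.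

Compound 4 `C=CCn1c(-c2cc(OC)c(OC)cc2C=O)cc2ccccc2c1=O` has not yet been measured. It arises from compound 2 by methoxy in place of hydrogen on an aromatic carbon. Among the compounds with values here, this is the same kind of change as the one from compound 1 to compound 3, though the surroundings differ: in compound 3 the entering methoxy is para to a (methoxymethoxy)methyl group, whereas in compound 4 it is para to a formyl group. In this assay the step from compound 2 to compound 4 is expected to be a 1.6-fold lower number from compound 2 to compound 4 (0.21 log units; within the scatter), a size that rests on the earlier step of a 1.8-fold lower number from compound 1 to compound 3 (0.25 log units; within the scatter). Compound 4 is therefore estimated at 55000 nM, with a range from 22000 nM to 130000 nM.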

Compound 4, half-maximal inhibitory concentration: 67600 nM
The estimate for compound 4 lay 1.2-fold (0.09 log units) below the measured number; low and high end bracket the measured number.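

In this assay, methoxy in place of hydrogen on the aromatic carbon para to a formyl group gives a 1.3-fold lower number from compound 2 to compound 4 (0.12 log units; within the scatter). Set beside the same change on the other core, the two steps do not differ: the same change on two cores in this assay, a 1.8-fold lower number (0.25 log units; within the scatter) from compound 1 to compound 3 and a 1.3-fold lower number (0.12 log units; within the scatter) from compound 2 to compound 4, 1.3-fold (0.13 log units) apart, within the scatter of two such steps The result shows that, across these two pairs, the change behaves alike on both cores, with no sign that the core alters its outcome; it does not show that methoxy has a real effect on either core, as each step on its own lies within the scatter, and agreement between two such small steps says little about how a larger effect would carry over.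

The compounds shown leave open whether an amine, a carboxylic acid or a longer chain in place of the methoxy would give a step beyond the scatter on either core. On these data alone, whether the same agreement holds on a further core, or in a different assay, also remains open.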